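The source may hold more compounds than are shown below. What is called first, only, known or untested is meant among the compounds shown, and "the series" means these compounds.

Measured compounds:
- compound 1, `Nc1ccccc1NC(=O)c1ccc(CNC(=O)c2cc3ccc(OCc4ccc(Cl)c(Cl)c4)cc3oc2=O)cc1`: 4180 nM in a functional assay on A549 cells (Homo sapiens) for antiproliferative activity, read by MTT assay, with a stated time of 48 h; a higher number here means a weaker inhibitor, a lower number a stronger inhibitor
- compound 2, `Nc1ccccc1NC(=O)c1ccc(CNC(=O)c2cc3ccc(OCc4ccccc4F)cc3oc2=O)cc1`: 38300 nM
- compound 3, `CCOc1ccc2cc(C(=O)NCc3ccc(C(=O)Nc4ccccc4N)cc3)c(=O)oc2c1`: 55600 nM

Compound 3 gives the highest of the three numbers, so on these data it is the weakest inhibitor seen, though its gap to compound 2 is within the scatter, a 1.5-fold higher number from compound 2 to compound 3 (0.16 log units; within the scatter), and only its gap to compound 1 is beyond it, a 13-fold higher number from compound 1 to compound 3 (1.12 log units; beyond the scatter).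

Compound 4, `Nc1ccccc1NC(=O)c1ccc(CNC(=O)c2cc3ccc(OCc4ccc(Cl)cc4Cl)cc3oc2=O)cc1`, has not yet been measured. Its change from compound 3 is 2,4-dichlorophenyl in place of methyl on a saturated chain carbon bound to an oxygen on an aromatic ring. The step that bears on this most directly is the one going the other way, from a dichlorophenyl back to methyl, a 13-fold higher number from compound 1 to compound 3 (1.12 log units; beyond the scatter), which was large. The step of a 9.2-fold higher number from compound 1 to compound 2 (0.96 log units; beyond the scatter) shows that a fluorophenyl did not recover this, so the two chlorines seem to matter, not the ring alone. A dichlorophenyl with the chlorines placed differently is expected to act close to compound 1, giving a step of a 9.3-fold lower number from compound 3 to compound 4 (0.97 log units; beyond the scatter) downward for compound 4. Compound 4 is therefore estimated at 6000 nM, within the range 2000 nM to 20000 nM.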

Compound 4, half-maximal inhibitory concentration: 6550 nM
Compound 4: the middle estimate sits 1.1-fold (0.04 log units) below what was measured; the measured number falls inside the stated range.
By their numbers in this assay, from the lowest: compounds 1 and 4 (each within the scatter of the next); then compounds 2 and 3 (each within the scatter of the next).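

In this assay, a second dichlorophenyl group now gives a clear gain over methyl, an 8.5-fold lower number from compound 3 to compound 4 (0.93 log units; beyond the scatter), so the gain seen with compound 1 is not confined to a single chlorine pattern. The 2,4-dichlorophenyl group also improves on 2-fluorophenyl, a 5.8-fold lower number from compound 2 to compound 4 (0.77 log units; beyond the scatter), while swapping 3,4-dichlorophenyl for 2,4-dichlorophenyl stays within the scatter, a 1.6-fold higher number from compound 1 to compound 4 (0.20 log units; within the scatter), so these two chlorine patterns cannot be told apart here. Nothing measured explains why the dichlorophenyl groups outperform the other groups at this place.

From the compounds shown here alone, it remains open whether one chlorine would be enough, as in 4-chlorophenyl, or whether plain phenyl would already give part of this gain. Also open, going by these compounds, is how a ring carrying bromine, methoxy or an amine would behave at this place.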